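Aryl swap at the saturated ring carbon: step to compound 4

The source may report more compounds than this note shows. Statements on the series, on what has been measured and on what is new or still open speak of the compounds shown alone.

The series keeps one core and varies the aryl group on a saturated ring carbon. Compound 1 `O=C1CSC(c2ccc(O)cc2)N1CCN1CCCCC1` carries a 4-hydroxyphenyl there; in an ADME assay on Vero cells (Chlorocebus sabaeus) for cytotoxicity, read by neutral red uptake, tested at 49 ug/mL (a lower number here means a stronger effect, a higher number a weaker effect of the compound at the concentration tested), compound 1 gives 96%. Compound 2 `O=C1CSC(c2cccc(F)c2)N1CCN1CCCCC1` carries a 3-fluorophenyl, and in this assay compound 2 gives 97%. Compound 3 `O=C1CSC(c2ccccc2Cl)N1CCN1CCCCC1` carries a 2-chlorophenyl; in this assay compound 3 gives 100%. The steps of a number 4 percentage points higher from compound 1 to compound 3 (within the scatter) and a number 3 percentage points higher from compound 2 to compound 3 (within the scatter) are both within the scatter, as is a number 1 percentage points higher from compound 1 to compound 2 (within the scatter), so the three numbers cannot be separated.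

Compound 4 `O=C1CSC(c2ccc(Cl)cc2)N1CCN1CCCCC1` differs from compound 3 only in the aryl group: 4-chlorophenyl in place of 2-chlorophenyl on a saturated ring carbon. Every measured step in this set is a change of the aryl at the same saturated ring carbon, and none of them moved the read-out beyond the scatter. On that basis the step of a number 2 percentage points lower from compound 3 to compound 4 (within the scatter) is expected to stay within the scatter, with no direction beyond it. In this assay compound 4 is therefore estimated at 98%, with a range from 92% to 100%.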

Compound 4, a percentage reported as activity, at one concentration (the size of the read-out at that concentration, not a potency): 84%
Compound 4: the middle estimate sits 14 percentage points above what was measured; measured number below the stated range.
By their numbers in this assay, from the lowest: compound 4; then compounds 1, 2 and 3 (each within the scatter of the next).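

The aryl group at this saturated ring carbon can move the read-out after all: 4-chlorophenyl in place of 2-chlorophenyl gives a number 16 percentage points lower from compound 3 to compound 4 (beyond the scatter) in this assay, with the same atoms joined differently, so the placement of the chlorine alone is enough for a step beyond the scatter. The other two steps run the same way, with a number 13 percentage points lower from compound 2 to compound 4 (beyond the scatter) for 4-chlorophenyl in place of 3-fluorophenyl and a number 12 percentage points lower from compound 1 to compound 4 (beyond the scatter) for chloro in place of hydroxy on an aromatic carbon, which sets compound 4 apart from the other three as the one with the stronger effect. Nothing available explains this shift.

Going by these compounds, whether the step is specific to chloro remains open, since 4-bromophenyl, 4-methoxyphenyl or 4-methylphenyl could show whether other groups in that place follow compound 4 or compound 1. A single compound also leaves open whether the step would hold on a different amine side chain.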